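Amide aryl swap on the cyclopropyl sulfonamide series

This account rests on a few compounds, and the source may have more. Where it says the series, first, only, none or still open, it means among the compounds named here.

Compound 2 `O=C(c1ccc(OC(F)(F)F)cc1)N1CCC(N(C2CC2)S(=O)(=O)c2cccc(C(F)(F)F)c2)CC1` gives 300 nM in an assay on HEK293 cells for inhibition of Voltage-dependent N-type calcium channel subunit alpha-1B (Homo sapiens), read by FLIPR and calcium flux, in the presence of a further agent that is not named here (on this read-out higher numbers stand for weaker inhibition and lower numbers for stronger inhibition), the highest of the three numbers; compound 1 `CCCN(C1CCN(Cc2c(OC)cccc2OC)CC1)S(=O)(=O)c1cccc(C(F)(F)F)c1` gives 120 nM and compound 3 `COc1cccc(OC)c1CN1CCC(N(C2CC2)S(=O)(=O)c2cccc(C(F)(F)F)c2)CC1` gives 60 nM. For the measured compounds named here, the only measured single-point step, a 2.0-fold lower number from compound 1 to compound 3 (0.30 log units; within the scatter), concerns the substituent on the sulfonamide nitrogen and not the group on the carbonyl carbon. Compound 4 `CS(=O)(=O)c1ccccc1C(=O)N1CCC(N(C2CC2)S(=O)(=O)c2cccc(C(F)(F)F)c2)CC1` differs from compound 2 by 2-(methylsulfonyl)phenyl in place of 4-(trifluoromethoxy)phenyl on a carbonyl carbon. Going by the values given here, no measured step bears on this change, so the expected size of step in this assay is none beyond the scatter, a 1.2-fold higher number from compound 2 to compound 4 (0.07 log units; within the scatter), carried with a wide range. Compound 4 is therefore estimated at 350 nM, with a range from 100 nM to 1500 nM.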

Compound 4, half-maximal inhibitory concentration: 660 nM
For compound 4 the middle estimate is 1.9-fold (0.28 log units) below the measured one, and the stated range covers the measured number.
By their numbers in this assay, from the lowest: compounds 3 and 1 (each within the scatter of the next); then compound 2; then compound 4.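

On the carbonyl carbon of the cyclopropyl sulfonamide series, the aryl group matters in this assay: 2-(methylsulfonyl)phenyl in place of 4-(trifluoromethoxy)phenyl gives a 2.2-fold higher number from compound 2 to compound 4 (0.34 log units; beyond the scatter), a modest step and the only one at this position. The swap alters both the substituent and its numbered place on the phenyl, and this single step cannot separate the two. Nothing on hand accounts for the step.

Open, on these data alone, is how unsubstituted phenyl or 4-(methylsulfonyl)phenyl would read on the same carbonyl carbon. Also open, as far as these compounds go, is whether a phenyl bearing an amine or a carboxylic acid would stay within this range.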